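A few compounds are considered here, and "the series" means these few. Any claim that something is new, unique, unknown or untested is made for them only; others in the source may bear on it.

Measured compounds in a functional assay on MCF7 cells (Homo sapiens) for antiproliferative activity, read by MTT assay, with a stated time of 72 h; on this read-out higher numbers stand for weaker inhibition and lower numbers for stronger inhibition:
Compound 1, `CCCNC(=O)c1cc(Oc2ccc(NC(=O)c3nn(-c4ccc(C)cc4)c(=O)cc3C)cc2F)ccn1`, gives 34600 nM.
Compound 2, `CCCNC(=O)c1cc(Oc2ccc(NC(=O)c3nn(-c4ccc(Br)cc4F)c(=O)cc3C)cc2F)ccn1`, gives "not active" (no number reported), reported without a number.
Compound 3, `CNC(=O)c1cc(Oc2ccc(NC(=O)c3nn(-c4cccc(C(F)(F)F)c4)c(=O)cc3C)cc2F)ccn1`, gives 45800 nM.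

Of the two numbers seen so far, compound 3 has the higher one, with compound 1 the nearest, and the gap between these two falls within the usual scatter of this assay, so no order between them can be claimed. Compound 2 contributes no number at all.

Compound 4, `CCCNC(=O)c1cc(Oc2ccc(NC(=O)c3nn(-c4cccc(C(F)(F)F)c4)c(=O)cc3C)cc2F)ccn1`, has not been measured. It differs from compound 3 in one place: ethyl in place of hydrogen on a saturated chain carbon bound to an amide-type nitrogen. Among the measured compounds shown here, no pair of measured compounds isolates this change on its own, so its effect cannot be read directly. What can be said is that compound 1 already carries the propylcarbamoyl group and compound 1 gives 34600 nM, a number close to that of compound 3. On this basis the step of a 1.1-fold lower number from compound 3 to compound 4 (0.06 log units; within the scatter) is expected to be small, not beyond the scatter, in either direction. Compound 4 is therefore estimated at 40000 nM, with a range from 15000 nM to 120000 nM, and with some chance that, like compound 2, only a limit is reported.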

Compound 4, half-maximal inhibitory concentration: 30000 nM
Estimate against measurement, compound 4: 1.3-fold (0.12 log units) above; the range from low to high includes it.
By their numbers in this assay, from the lowest: compounds 4, 1 and 3 (each within the scatter of the next).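

Within this assay, exchanging methylcarbamoyl for propylcarbamoyl brings a 1.5-fold lower number from compound 3 to compound 4 (0.18 log units; within the scatter) and gives the first view of this change with the rest of the molecule held constant: the ethyl extension of the chain on the amide-type nitrogen is tolerated without a shift that can be told from the scatter. A second clean comparison, 3-(trifluoromethyl)phenyl in place of 4-methylphenyl on the aromatic nitrogen, brings a 1.2-fold lower number from compound 1 to compound 4 (0.06 log units; within the scatter) and so shows that this exchange also stays within the scatter when the propylcarbamoyl group is present. Nothing further was measured that could explain why these exchanges leave the number so little changed.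

As far as these compounds go, whether a still longer chain such as butyl, or a chain ending in an amine or a carboxylic acid, would move the number beyond the scatter remains open. Compound 2 also carries the propylcarbamoyl group but has no number, so any step involving its different group on the aromatic nitrogen cannot be read.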